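The compounds below may be only part of what the source reports. "The series", "measured", "known", "first", "only" and "open" are said of these compounds alone.

Measured so far:
compound 1 `COc1ccc(C2=NN(C3=NC(c4ccccc4)CS3)C(c3ccc4ccccc4c3)C2)cc1` with 1860 nM in a functional assay on HeLa cells (Homo sapiens) for inhibition, read by CCK-8 assay, with a stated time of 48 h; on this read-out lower numbers stand for stronger inhibition and higher numbers for weaker inhibition
compound 2 `c1ccc(C2=NN(C3=NC(c4ccccc4)CS3)C(c3ccc4ccccc4c3)C2)cc1` with 3860 nM in this assay

For the measured compounds named here, compound 2 stands at the higher of the two numbers, with compound 1 the only neighbour; the single step recorded, a 2.1-fold higher number from compound 1 to compound 2 (0.32 log units; beyond the scatter), is a modest shift and lies beyond the scatter, and it came from removing the methoxy group that sits on the same aromatic ring.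

Compound 3 `Brc1ccc(C2=NN(C3=NC(c4ccccc4)CS3)C(c3ccc4ccccc4c3)C2)cc1` is compound 2 with bromo in place of hydrogen on an aromatic carbon. Going by the values given here, no step with a bromo group has been measured, so the only bearing evidence is that one step from compound 1 to compound 2, which showed that a group at this para position, on this aromatic carbon of a six-membered aromatic ring of carbon only, can lower the number by a modest amount. A bromo group is not a methoxy group, and the direction cannot be read across with confidence, so the expectation for compound 3 is a step of a 1.4-fold lower number from compound 2 to compound 3 (0.16 log units; within the scatter) in this assay, small and possibly within the scatter. Compound 3 is therefore estimated at 2700 nM, with a range from 1100 nM to 6500 nM.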

Compound 3, half-maximal inhibitory concentration: 4960 nM
Beside the measured number, compound 3's estimate is 1.8-fold (0.26 log units) below it; low and high end bracket the measured number.
By their numbers in this assay, from the lowest: compound 1; then compounds 2 and 3 (each within the scatter of the next).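

In this assay, putting bromo in place of hydrogen on this aromatic carbon, para to a large group, gives a 1.3-fold higher number from compound 2 to compound 3 (0.11 log units; within the scatter), so the phenyl and 4-bromophenyl compounds cannot be told apart on this read-out. Replacing methoxy with bromo at the same place gives a 2.7-fold higher number from compound 1 to compound 3 (0.43 log units; beyond the scatter), and compound 1 now stands apart from both other compounds, with the lowest number of the three. The earlier step could have meant that any group at this position lowers the number, but compound 3 goes against that reading, and among the three groups shown only methoxy separates from the rest.

As far as these compounds go, whether an amine, a hydroxyl group or a carboxylic acid at this place would behave like methoxy or like bromo stays open, as does the behaviour of a longer chain such as ethoxy. The compounds shown also leave open whether the separation seen with methoxy would hold if the shared core were changed elsewhere.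

No measurement among the data given explains why methoxy and bromo part in this way.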